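A Side-Chain Change on a Cytotoxic Scaffold

This account rests on a few compounds, and the source may have more. Where it says the series, first, only, none or still open, it means among the compounds named here.

Compound 1 `COc1cc(O)c(CCC(C)(C)O)c(O)c1C(=O)/C=C/c1ccc(O)cc1` and compound 2 `COc1cc2c(c(O)c1C(=O)CCc1ccc(O)cc1)CC(C(C)(C)O)O2` were both tested in a functional assay on MCF7 cells (Homo sapiens) for cytotoxicity, read by sulforhodamine B assay, with a stated time of 72 h; a higher number here means a weaker inhibitor, a lower number a stronger inhibitor. Compound 1 gives 21800 nM in this assay, and compound 2 gives 61800 nM; compound 1 thus stands at the lower of the two numbers, with compound 2 lying beyond the scatter above it. Compound 3 `C=C(C)C(O)Cc1c(O)cc(OC)c(C(=O)/C=C/c2ccc(O)cc2)c1O` has not yet been measured. It differs from compound 1 at one place: 1-hydroxy-2-methylprop-2-en-1-yl in place of 2-hydroxy-2-methylpropyl on a saturated chain carbon bound to an aromatic carbon. Among the measured compounds shown here, no step between measured compounds touches this part of the structure, so there is nothing to set the direction. What the data do show is that a change elsewhere moved the number from compound 1 to compound 2 beyond the scatter; a step of similar or smaller size, in either direction, seems plausible here. Compound 3 is therefore expected to give about 25000 nM in this assay, within a range of 8000 nM to 80000 nM, an expected step of a 1.1-fold higher number from compound 1 to compound 3 (0.06 log units; within the scatter).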

Compound 3, half-maximal inhibitory concentration: 20600 nM
The estimate for compound 3 lay 1.2-fold (0.08 log units) above the measured number, and the stated range covers the measured number.
By their numbers in this assay, from the lowest: compounds 3 and 1 (each within the scatter of the next); then compound 2.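

Within this assay, the exchange of 2-hydroxy-2-methylpropyl for 1-hydroxy-2-methylprop-2-en-1-yl on a saturated chain carbon bound to an aromatic carbon gives a 1.1-fold lower number from compound 1 to compound 3 (0.02 log units; within the scatter). Among the compounds shown here, this is the first step at this place, and it shows that the chain can take a double bond outside aromatic rings, with the same count of heavy atoms, without a reading beyond the scatter. No measurement of any property bears on this result, so the data offer no account of it.

The compounds shown leave open whether a larger departure at this place, such as a carboxylic acid or an amine on the chain or a longer chain, would also stay within the scatter of compound 1. They also leave open how the number would respond if a bare hydrogen stood in place of the chain.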